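Swapping fluoro for methoxy: what to expect

This account rests on a few compounds, and the source may have more. Where it says the series, first, only, none or still open, it means among the compounds named here.

Three related compounds have so far been tested in a functional assay on CCRF-CEM cells (Homo sapiens) for inhibition (on this read-out lower numbers stand for stronger inhibition and higher numbers for weaker inhibition), and two of them gave true numbers. Compound 1 (`Cc1ccc(/C=C2\Cc3ccccc3C2=O)cc1`) gives 67100 nM while compound 3 (`O=C1/C(=C/c2ccc(F)cc2)CCCc2ccccc21`) gives 20000 nM and so holds the lower of these two numbers, by a gap beyond the usual scatter of repeat measurements. Compound 2 (`O=C1/C(=C/c2ccc(Br)cc2)CCc2ccccc21`) gives > 500000 nM and this is a limit of the assay, not a number.

The next compound, compound 4 (`COc1ccc(/C=C2\CCCc3ccccc3C2=O)cc1`), has methoxy in place of fluoro on an aromatic carbon, para to a large group (methoxy in place of fluoro on an aromatic carbon). Within the data shown here, no measured pair here differs by one change alone, so the swap has no direct precedent. Compound 3, at 20000 nM in this assay, is the natural starting point. The expected change, a 1.3-fold higher number from compound 3 to compound 4 (0.10 log units; within the scatter), is small and stays within the scatter, with only a slight lean toward weaker inhibition. For compound 4 the estimated value is 25000 nM, with an expected range from 7000 nM to 100000 nM.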

Compound 4, half-maximal inhibitory concentration: 350 nM
Beside the measured number, compound 4's estimate is 71-fold (1.85 log units) above it; the measured number lies below the stated range.
By their numbers in this assay, from the lowest: compound 4; then compound 3; then compound 1. At a limit, above all of these: compound 2.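

In this assay, among these compounds, the swap of fluoro for methoxy, on an aromatic carbon para to a large group, gives a 57-fold lower number from compound 3 to compound 4 (1.76 log units; beyond the scatter) and is the first step here between compounds that differ in one place. It shows that this single position on the shared core can move the read-out strongly, and that methoxy is far better tolerated there than the earlier numbers suggested. Nothing at hand gives a reason for the size of this step.

From the compounds shown here alone, only fluoro and methoxy can be compared at this position, so it stays open whether a hydroxyl, an ethoxy group or an amine there would give a similar drop. Going by these compounds, it also stays open whether methoxy would have the same effect on the cores of compound 1 and compound 2.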